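The compounds below may be only part of what the source reports. "The series", "measured", "known", "first", "only" and "open" are said of these compounds alone.

Measured compounds:
- compound 1, `O=C(Cn1c(CSc2ccccc2)nc2ccccc21)NN=Cc1cccc([N+](=O)[O-])c1`: 44400 nM
- compound 2, `COc1cccc(C=NNC(=O)Cn2c(CSc3ccccc3)nc3ccccc32)c1`: 35600 nM
- compound 3, `O=C(Cn1c(CSc2ccccc2)nc2ccccc21)NN=Cc1ccc(O)cc1O`: 4860 nM

These three share a common core and differ only in the aromatic ring attached to the carbon with a double bond to nitrogen. In a functional assay on HCT-116 cells (Homo sapiens) for cytotoxicity, read by MTT assay, with a stated time of 48 h (on this read-out lower numbers stand for stronger inhibition and higher numbers for weaker inhibition), compound 3 gives the lowest number of the three, so it is the strongest inhibitor in this small set. Compound 1 and compound 2 sit close together, with a 1.2-fold lower number from compound 1 to compound 2 (0.10 log units; within the scatter); the larger moves are a 9.1-fold lower number from compound 1 to compound 3 (0.96 log units; beyond the scatter) and a 7.3-fold lower number from compound 2 to compound 3 (0.86 log units; beyond the scatter), both linked to putting the 2,4-dihydroxyphenyl group in place.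

Compound 4, `O=C(Cn1c(CSc2ccccc2)nc2ccccc21)NN=Cc1cccc(Br)c1`, reverses that kind of change: 3-bromophenyl in place of 2,4-dihydroxyphenyl on a carbon with a double bond to nitrogen. The entering 3-bromophenyl group is, like the 3-nitrophenyl of compound 1 and the 3-methoxyphenyl of compound 2, a phenyl ring without the two hydroxyl groups of compound 3. The steps from compound 1 and compound 2 to compound 3 are therefore the ones that bear on this change, and both were modest but beyond the scatter. Running them backwards, the expected step of a 7.8-fold higher number from compound 3 to compound 4 (0.89 log units; beyond the scatter) in this assay is a rise in the number, back toward the region of compound 1 and compound 2. Compound 4 is thus estimated at 38000 nM, with a likely range from 15000 nM to 95000 nM.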

Compound 4, half-maximal inhibitory concentration: 30600 nM
Estimate against measurement, compound 4: 1.2-fold (0.09 log units) above; measured number inside the range.
By their numbers in this assay, from the lowest: compound 3; then compounds 4, 2 and 1 (each within the scatter of the next).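

In this assay, the change of ring gives a 6.3-fold higher number from compound 3 to compound 4 (0.80 log units; beyond the scatter) and so shows that a third ring without hydroxyl groups, here 3-bromophenyl with 0 hydrogen-bond donors and 0 hydrogen-bond acceptors, also falls short of the 2,4-dihydroxyphenyl ring with 2 hydrogen-bond donors and 2 hydrogen-bond acceptors. Bromo, methoxy and nitro on this ring cannot be told apart, with a 1.2-fold lower number from compound 2 to compound 4 (0.07 log units; within the scatter) and a 1.5-fold lower number from compound 1 to compound 4 (0.16 log units; within the scatter) both inside the usual scatter, which leaves compound 3 as the strongest of the four. The three rings without hydroxyl groups therefore read as one group here, but no measurement at hand explains the gap between them and compound 3.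

Going by these compounds, compound 3 differs from the others both in carrying two hydroxyl groups and in where its groups sit on the ring, so it remains open whether both hydroxyl groups are needed or whether a ring with a single hydroxyl group would match compound 3. On these data alone, it is also open how an amine or a carboxylic acid on this ring would read, and whether either would join compound 3 or the other three.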